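Swapping the side chain on the amide nitrogen

The compounds below may be only part of what the source reports. "The series", "measured", "known", "first", "only" and "open" are said of these compounds alone.

Compound 2 `NC[C@H](NC(=O)c1ccc(C#Cc2ccccc2)cc1)C(=O)NO` carries a hydroxamic acid and an aminomethyl-bearing side chain on the shared core. In a physicochemical assay for lipophilicity (on this read-out higher numbers stand for higher lipophilicity and lower numbers for lower lipophilicity), compound 2 gives 2. Compound 1 `O=C(N[C@H](CO)C(=O)NO)c1ccc(C#Cc2ccccc2)cc1` differs from it only in the side chain, and in this assay compound 1 gives 2. Among the measured compounds shown here, the one measured step, no change at the digits printed from compound 1 to compound 2 (within the scatter), is the only comparison in hand, and it shows that exchanging one short polar side chain for another left the read-out where it was.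

Compound 3 `CC(C)C(NC(=O)c1ccc(C#Cc2ccccc2)cc1)C(=O)NO` is not yet measured. Its difference from compound 2 is a group of 8 heavy atoms (5 carbon, 1 nitrogen, 2 oxygen; no ring) in place of a group of 7 heavy atoms (3 carbon, 2 nitrogen, 2 oxygen; no ring), on an amide-type nitrogen. For the measured compounds named here, no measured step covers this particular exchange, so the expectation rests only on the two values known and on the size of the change, which replaces a chain bearing two nitrogens with a 1-(hydroxycarbamoyl)-2-methylpropyl chain bearing one. A step beyond the scatter towards higher values is expected, namely a number 0.80 log units higher from compound 2 to compound 3 (beyond the scatter). For compound 3 the estimated value in this assay is 2.8, with a range from 2 to 3.6.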

Compound 3, distribution coefficient: > 3
Compound 3: no number, only a limit; the forecaster's own chance of this, stated with the estimate: 5%; middle value at least 0.20 log units from the limit.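

The two earlier compounds left it possible that this side chain hardly matters for this assay, but the result shows that the read-out does respond to a change at this place on the amide-type nitrogen: exchanging the aminomethyl-bearing chain for 1-(hydroxycarbamoyl)-2-methylpropyl gives a number at least 1.00 log units higher from compound 2 to compound 3 (beyond the scatter). Starting from the hydroxyl-bearing chain, the same entering group gives a number at least 1.00 log units higher from compound 1 to compound 3 (beyond the scatter), so the two level compounds both part from compound 3 by a step beyond the scatter. The read-out of compound 3 is a limit and not a number: the limit of > 3 in this assay, at which 1 of the 3 values shown sits.

The entering group differs from the leaving ones in several counted features at once, including its carbons, its nitrogens or oxygens, and its hydrogen-bond donors and acceptors, and the three compounds cannot separate which of these goes with the step, nor can they show what the entering chain's lack of a defined stereocentre contributes. On these data alone, how a longer carbon chain, a phenyl ring or a carboxylic acid in this side chain would read in this assay also remains open.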